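This account rests on a few compounds, and the source may have more. Where it says the series, first, only, none or still open, it means among the compounds named here.

Measured in a functional assay on SH-SY5Y cells (Homo sapiens) for cytotoxicity, read by MTT assay, with a stated time of 72 h; on this read-out lower numbers stand for stronger inhibition and higher numbers for weaker inhibition:
- compound 1 `O=C1c2c[n+]([O-])c3ccccc3c2C(=O)c2c1c1ccccc1n2Cc1cn([C@H]2O[C@H](CO)[C@@H](O)[C@H]2O)nn1`: 1340 nM
- compound 2 `O=C1c2c[n+]([O-])c3ccccc3c2C(=O)c2c1c1ccccc1n2CCCCn1ccnc1`: 130 nM
- compound 3 `CC1(C)OCC(Cn2cc(Cn3c4c(c5ccccc53)C(=O)c3c[n+]([O-])c5ccccc5c3C4=O)nn2)O1`: 230 nM

In this assay, compound 3 at 230 nM and compound 2 at 130 nM lie within the scatter of each other, while compound 1 stands clearly apart from compound 3.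

The next structure is compound 4 `CC1(C)O[C@@H](CO)[C@H](Cn2cc(Cn3c4c(c5ccccc53)C(=O)c3c[n+]([O-])c5ccccc5c3C4=O)nn2)O1`, which differs from compound 3 by 5-(hydroxymethyl)-2,2-dimethyl-1,3-dioxolan-4-yl in place of 2,2-dimethyl-1,3-dioxolan-4-yl on a saturated chain carbon bound to an aromatic nitrogen. In words, 5-(hydroxymethyl)-2,2-dimethyl-1,3-dioxolan-4-yl takes the place of 2,2-dimethyl-1,3-dioxolan-4-yl on a saturated chain carbon bound to an aromatic nitrogen.

For the measured compounds named here, only one measured step bears on this change, a 5.8-fold lower number from compound 1 to compound 3 (0.77 log units; beyond the scatter). It is a modest step beyond the scatter, and it replaces the 3,4-dihydroxy-5-(hydroxymethyl)oxolan-2-yl group of compound 1. Compound 4 regains a hydroxymethyl, so it moves part of the way back towards compound 1 in structure. It keeps the dimethyl dioxolane of compound 3, so only a fraction of that step is expected to return, in the direction of a higher number. The expected change is a 1.5-fold higher number from compound 3 to compound 4 (0.18 log units; within the scatter), which may not clear the scatter. With a single step as guide, this expectation is weak. For compound 4 the estimated value is 350 nM, with an expected range of 150 nM to 900 nM.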

Compound 4, half-maximal inhibitory concentration: > 1000 nM
Compound 4: no number, only a limit; the forecaster's own chance of this, stated with the estimate: 3%; middle value at least 2.8-fold (0.45 log units) from the limit.
By their numbers in this assay, from the lowest: compounds 2 and 3 (each within the scatter of the next); then compound 1.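

In this assay compound 4 gives > 1000 nM, which is a limit of the assay and not a number. Setting 5-(hydroxymethyl)-2,2-dimethyl-1,3-dioxolan-4-yl in place of 2,2-dimethyl-1,3-dioxolan-4-yl on a saturated chain carbon bound to an aromatic nitrogen gives an at least 4.3-fold higher number from compound 3 to compound 4 (0.63 log units; beyond the scatter), so with the dimethyl dioxolane kept, this one added hydroxymethyl is enough to move the number beyond the scatter, something the earlier compounds could not show, as compound 1 and compound 3 differ in the whole group on an aromatic nitrogen. The step between compound 1 and compound 4 cannot be read through the limit, so these two cannot be placed relative to each other.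

The compounds shown leave open whether the step follows the hydroxyl of the hydroxymethyl or the added carbon, a question that a methoxymethyl or a plain methyl in its place would address. Also open, on these data alone, are how far the number of compound 4 lies past its limit and whether its defined stereocentres play any part in the step.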